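A few compounds are considered here, and "the series" means these few. Any claim that something is new, unique, unknown or untested is made for them only; others in the source may bear on it.

Measured so far in a functional assay on A498 cells (Homo sapiens) for inhibition, read by sulforhodamine B assay, with a stated time of 48 h; on this read-out lower numbers stand for higher toxicity in this test and higher numbers for lower toxicity in this test: compound 1 `Nc1cc(N)c2nc(-c3ccccc3)c(Oc3ccc(Cl)c(Cl)c3)nc2c1` sits at the assay limit of < 100000 nM, which is a limit and not a number. Compound 2 `Nc1cc(N)c2nc(-c3ccccc3)c(NCc3ccc(F)cc3)nc2c1` gives 57500 nM. Compound 3 `COc1ccc(Sc2nc3cc(N)cc(N)c3nc2-c2ccccc2)cc1` gives 60300 nM.

Among the two readable numbers compound 3 stands highest, and the step of a 1.0-fold higher number from compound 2 to compound 3 (0.02 log units; within the scatter) places it next to compound 2. Compound 4 `Nc1cc(N)c2nc(-c3ccccc3)c(Sc3ccc(Cl)c(Cl)c3)nc2c1` is reached from compound 3 by 3,4-dichlorophenyl in place of 4-methoxyphenyl on a sulfur. Among the compounds with values here, the only measured step that touches a dichlorinated ring is a step that the limit leaves unreadable from compound 1 to compound 3, and it cannot be read because the limit of < 100000 nM in this assay, at which 1 of the 3 values shown sits, hides its size. With no readable guide, no change beyond the scatter is expected, an estimated step of a 1.0-fold lower number from compound 3 to compound 4 (0.00 log units; within the scatter). Compound 4 is therefore estimated at 60000 nM, with a range from 25000 nM to 120000 nM.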

Compound 4, concentration lethal to 50% of the cells: 57500 nM
For compound 4 the middle estimate is 1.0-fold (0.02 log units) above the measured one; the measured number falls inside the stated range.
By their numbers in this assay, from the lowest: compounds 2, 4 and 3 (each within the scatter of the next).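

On a sulfur, 3,4-dichlorophenyl in place of 4-methoxyphenyl gives a 1.0-fold lower number from compound 3 to compound 4 (0.02 log units; within the scatter) in this assay, so swapping these two rings does not move the number beyond the scatter. Replacing (4-fluorobenzyl)amino with (3,4-dichlorophenyl)sulfanyl gives no change at the digits printed from compound 2 to compound 4 (within the scatter), so this change of the whole group also leaves the number within the scatter. The step from compound 1 to compound 4 cannot be read, because compound 1 gives only a limit: the limit of < 100000 nM in this assay, at which 1 of the 4 values shown sits.

The compounds shown leave open whether a carboxylic acid or a longer chain in place of these rings on the sulfur would give a number beyond the scatter.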